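A few compounds are considered here, and "the series" means these few. Any claim that something is new, unique, unknown or untested is made for them only; others in the source may bear on it.

Measured so far in a functional assay on K562 cells (Homo sapiens) for cytotoxicity, read by MTT assay, with a stated time of 48 h; a higher number here means a weaker inhibitor, a lower number a stronger inhibitor:
- compound 1 `O=C(CN[C@H]1CCN(S(=O)(=O)Cc2ccccc2)C1)N1CCN(Cc2ccccc2Cl)CC1`: 9000 nM
- compound 2 `O=C(CN[C@H]1CCN(S(=O)(=O)Cc2ccccc2)C1)N1CCN(Cc2ccc(Cl)cc2)CC1`: 9200 nM

Compound 2 stands level with compound 1 on these numbers, and the two cannot be separated. Next in the series is compound 3 `O=C(CN[C@H]1CCN(S(=O)(=O)Cc2ccccc2)C1)N1CCN(Cc2ccccc2F)CC1`, with the change (2-fluorophenyl in place of 4-chlorophenyl on a saturated chain carbon bound to an amine nitrogen in a ring). In short, 2-fluorophenyl comes in place of 4-chlorophenyl on a saturated chain carbon bound to an amine nitrogen in a ring, which also reads as 4-chlorobenzyl to 2-fluorobenzyl.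

Among the compounds with values here, one measured step bears on this: a 1.0-fold higher number from compound 1 to compound 2 (0.01 log units; within the scatter), with 4-chlorophenyl in place of 2-chlorophenyl at the same place. That step stays within the scatter. Within the data shown here, no measured compound carries fluorine, so the exchange of chlorine for fluorine has no direct measure, and the range is kept wide. Nothing shown points to a step beyond the scatter in this assay, and no direction is favoured.

The expected result is a 1.0-fold higher number from compound 2 to compound 3 (0.01 log units; within the scatter). Compound 3 is estimated at 9500 nM, with an expected range of 4000 nM to 22000 nM.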

Compound 3, half-maximal inhibitory concentration: 12600 nM
Compound 3: middle estimate off by 1.3-fold (0.12 log units), on the low side, within the range that was stated.
By their numbers in this assay, from the lowest: compounds 1, 2 and 3 (each within the scatter of the next).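

In this assay, this place on the saturated chain carbon bound to an amine nitrogen in a ring now has a first fluorine-bearing member, and 2-fluorophenyl in place of 4-chlorophenyl gives a 1.4-fold higher number from compound 2 to compound 3 (0.14 log units; within the scatter). The narrower reading is fluoro in place of chloro on an aromatic carbon, with 2-chlorophenyl and 2-fluorophenyl at the same place, which gives a 1.4-fold higher number from compound 1 to compound 3 (0.15 log units; within the scatter), so the identity of the halogen, like the earlier move of chlorine, does not separate the compounds on these numbers. No measurement is available that could explain this lack of separation.

The compounds shown hold only a single halogen on the phenyl ring, which leaves open whether a methoxy group, a nitrile, an amine or a carboxylic acid on that ring, or a longer chain in place of the benzyl group, would give a step beyond the scatter in this assay. Also open, going by these compounds, is how far the numbers depend on the rest of the shared core, since the phenylmethanesulfonyl end stays the same in compound 1, compound 2 and compound 3.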